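The source may report more compounds than this note shows. Statements on the series, on what has been measured and on what is new or still open speak of the compounds shown alone.

Measured in a functional assay (blood) for inhibition, with Homo sapiens as the target; a higher number here means a weaker inhibitor, a lower number a stronger inhibitor:
- Compound 1 `CC(C)(C)Sc1c(CC(C)(C)C(=O)O)n(Cc2ccc(Cl)cc2)c2ccc(OCc3ccc4cc(F)ccc4n3)cc12`: 880 nM
- Compound 2 `CC(C)(C)Sc1c(CC(C)(C)C(=O)O)n(Cc2ccc(Cl)cc2)c2ccc(OCc3cccc(Cl)n3)cc12`: 410 nM

Compound 2 stands lowest of the two, at 410 nM. Compound 3 `C[C@@H](COc1ccc2c(c1)c(SC(C)(C)C)c(CC(C)(C)C(=O)O)n2Cc1ccc(Cl)cc1)c1ccccn1` differs from it at one place, on a saturated chain carbon bound to an oxygen on an aromatic ring: 1-(pyridin-2-yl)ethyl in place of 6-chloropyridin-2-yl on a saturated chain carbon bound to an oxygen on an aromatic ring. Going by the values given here, one measured step bears on this place, the modest 2.1-fold lower number from compound 1 to compound 2 (0.33 log units; beyond the scatter). Among the compounds with values here, no measured compound carries 1-(pyridin-2-yl)ethyl, so the direction is uncertain, but a modest rise in this assay is expected. The estimate is a 1.7-fold higher number from compound 2 to compound 3 (0.23 log units; within the scatter). Compound 3 is expected at 700 nM, within an estimated range of 250 nM to 2000 nM.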

Compound 3, half-maximal inhibitory concentration: 280 nM
The estimate for compound 3 lay 2.5-fold (0.40 log units) above the measured number; low and high end bracket the measured number.
By their numbers in this assay, from the lowest: compounds 3 and 2 (each within the scatter of the next); then compound 1.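

In this assay, the place on a saturated chain carbon bound to an oxygen on an aromatic ring tolerates 1-(pyridin-2-yl)ethyl, with its defined stereocentre, as well as 6-chloropyridin-2-yl (a 1.5-fold lower number from compound 2 to compound 3 (0.17 log units; within the scatter)). Set against 6-fluoroquinolin-2-yl, the same group gives a step beyond the scatter (a 3.1-fold lower number from compound 1 to compound 3 (0.50 log units; beyond the scatter)). Nothing at hand explains either step. The compounds shown leave open whether the opposite configuration at that stereocentre gives a similar number, and how an amine or a longer chain would read at this place.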